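The source may report more compounds than this note shows. Statements on the series, on what has been measured and on what is new or still open speak of the compounds shown alone.

Measured compounds:
Compound 1 `COc1ccc(N(CC(=O)NCCCSc2ccccc2)C(=O)CCSC2=C(C)C(=O)c3ccccc3C2=O)cc1` in a functional assay on MCF7 cells (Homo sapiens) for cytotoxicity, read by MTT assay, with a stated time of 24 h (a higher number here means a weaker inhibitor, a lower number a stronger inhibitor), gives 16000 nM.
Compound 2 `COc1ccc(N(CC(=O)NCCC[Se]c2ccccc2)C(=O)CCSC2=C(C)C(=O)c3ccccc3C2=O)cc1` in this assay gives 8000 nM.
Compound 3 `COc1ccc(N(CC(=O)NCCCSc2ccccc2)C(=O)/C=C/c2ccccc2)cc1` in this assay gives only a limit of the assay, >= 100000 nM.

Among the measured compounds shown here, the single step between the first two compounds is a group of 7 heavy atoms (6 carbon, 1 selenium; one six-membered aromatic ring of carbon only) in place of a group of 7 heavy atoms (6 carbon, 1 sulfur; one six-membered aromatic ring of carbon only), on a saturated chain carbon, three bonds along the chain from an amide-type nitrogen. In this assay that step makes a 2.0-fold lower number from compound 1 to compound 2 (0.30 log units; within the scatter). Compound 3 keeps the side chain of compound 1 but has a different core; the difference between the two cores is not broken down here. Compound 4 `COc1ccc(N(CC(=O)NCCC[Se]c2ccccc2)C(=O)/C=C/c2ccccc2)cc1` has not been measured. It stands to compound 3 exactly as compound 2 stands to compound 1, the same change at the same place: a group of 7 heavy atoms (6 carbon, 1 selenium; one six-membered aromatic ring of carbon only) in place of a group of 7 heavy atoms (6 carbon, 1 sulfur; one six-membered aromatic ring of carbon only), on a saturated chain carbon, three bonds along the chain from an amide-type nitrogen. Because the earlier step made only a 2.0-fold lower number from compound 1 to compound 2 (0.30 log units; within the scatter) in this assay, the step from compound 3 to compound 4 is expected to be a number no higher from compound 3 to compound 4 (the limit leaves the size open) in this assay. Compound 3 sits at the limit of >= 100000 nM in this assay, at which 1 of the 3 values shown sits. Compound 4 is therefore expected to land near that same limit, estimated at 100000 nM, with a range from 40000 nM to 300000 nM, and a limit rather than a number is the likely outcome.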

Compound 4, half-maximal inhibitory concentration: >= 100000 nM
Compound 4: a limit, no number; the forecaster's own chance of this, stated with the estimate: 75%; the middle value lies on the limit itself.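

In this assay, compound 3 and compound 4 both give a limit of the assay rather than a number, so the step between them cannot be read. The compounds shown leave open whether putting selenium in place of sulfur in the side chain changes the result at all on the core of compound 3.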